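Cytotoxicity at the Limit: From Compound 3 to Compound 4

This account rests on a few compounds, and the source may have more. Where it says the series, first, only, none or still open, it means among the compounds named here.

Three compounds sharing one core were tested in an ADME assay on HFF cells (Homo sapiens) for cytotoxicity, read by MTT assay, with a stated time of 72 h; on this read-out lower numbers stand for stronger inhibition and higher numbers for weaker inhibition. Compound 1 `O=C1O/C(=C\Cn2cc(-c3ccc(Br)cc3)nn2)C(OCc2ccccc2)=C1OCc1ccccc1` carries a bromo group on its aromatic ring. In this assay compound 1 gives > 100000 nM, which is a limit of the assay rather than a number. Compound 2 `CCCCCc1ccc(-c2cn(C/C=C3\OC(=O)C(OCc4ccccc4)=C3OCc3ccccc3)nn2)cc1` carries a pentyl chain in place of the bromo. In this assay compound 2 gives > 100000 nM, again a limit. The step that the two limits leave unreadable from compound 1 to compound 2 therefore cannot be read. Compound 3 `CCCCCc1ccc(-c2cn(C[C@H](O)[C@H]3OC(=O)C(OCc4ccccc4)=C3OCc3ccccc3)nn2)cc1` keeps the 4-pentylphenyl group on a modified core. In this assay compound 3 gives > 100000 nM, once more a limit, so compound 3 stands at the limit of > 100000 nM in this assay, at which 3 of the 3 values shown sit, together with every other value shown.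

Compound 4 `O=C1O[C@H]([C@@H](O)Cn2cc(CCO)nn2)C(OCc2ccccc2)=C1OCc1ccccc1` differs from compound 3 by one change: 2-hydroxyethyl in place of 4-pentylphenyl on an aromatic carbon. Among the measured compounds shown here, no measured step speaks to this change, and the only step that was measured is itself unreadable. With every value sitting at the limit, no movement beyond the scatter is expected in this assay. Compound 4 is therefore expected to give 150000 nM, between 50000 nM and 500000 nM, most likely reported only as a limit. The expected step that the limit leaves unreadable from compound 3 to compound 4 is thus essentially none.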

Compound 4, half-maximal inhibitory concentration: 58500 nM
The estimate for compound 4 lay 2.6-fold (0.41 log units) above the measured number; the range from low to high includes it.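

Compound 4 is the only compound shown that gives a number rather than a limit, and the others sit together: the limit of > 100000 nM in this assay, at which 3 of the 4 values shown sit.

Among the compounds shown here, at this aromatic carbon of the five-membered aromatic ring, putting 2-hydroxyethyl in place of 4-pentylphenyl brings an at least 1.7-fold lower number from compound 3 to compound 4 (0.23 log units; that floor lies within the scatter) in this assay, so this position is the first place where a change produces a readable value. Compound 3 supplies only a limit, so the step has only a floor, and that floor alone does not establish a shift beyond the usual scatter.

This single change removes the six-membered aromatic ring, shortens the group from 11 heavy atoms to 3, and brings in a hydrogen-bond donor and acceptor, and the compounds shown cannot separate these differences from one another. An ethyl group, a 3-hydroxypropyl chain or an amine at this position would help show which of them goes with the readable value, and the same 2-hydroxyethyl group on the core of compound 2 would show whether the result holds beyond the core of compound 3.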